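This account rests on a few compounds, and the source may have more. Where it says the series, first, only, none or still open, it means among the compounds named here.

Compound 1, `O=[N+]([O-])c1ccc(S(=O)(=O)NC2=NCCN2C(=S)SN2CCn3c2nsc3=S)cc1`: >= 20000 nM
Compound 2, `O=S(=O)(NC1=NCCN1C(=S)SN1CCn2c1nsc2=S)c1ccc(Cl)c(Cl)c1`: >= 20000 nM

Both shown results in a functional assay on KYSE-510 cells (Homo sapiens) for antiproliferative activity, read by crystal violet staining, with a stated time of 96 h (a higher number here means a weaker inhibitor of growth, a lower number a stronger inhibitor of growth), are limits of the assay rather than numbers. For compound 1 the value >= 20000 nM is such a limit. For compound 2 the value >= 20000 nM is likewise a limit, so compound 2 stands at the edge of what this assay reports, as the limit of >= 20000 nM in this assay, at which 2 of the 2 values shown sit, records. The step that the two limits leave unreadable from compound 1 to compound 2 is consequently unreadable, since both of its ends are limits.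

Compound 3, `O=S(=O)(NC1=NCCN1C(=S)SN1CCn2c1nsc2=S)c1ccc(F)c(Cl)c1`, differs from compound 2 by fluoro in place of chloro on an aromatic carbon. Going by the values given here, the only measured step available bears on a different part of the same phenyl ring and gives no readable size, so no direction can be drawn from it. Compound 3 is therefore expected to stay at the limit as well, with the step that the limit leaves unreadable from compound 2 to compound 3 estimated as none beyond the scatter. The estimate for compound 3 is 25000 nM, between 10000 nM and 60000 nM.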

Compound 3, concentration for 50% growth inhibition: >= 20000 nM
Compound 3: a limit, no number; the forecaster's own chance of this, stated with the estimate: 85%; the middle value is on the limit's open side.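

Compound 3 also returns a limit rather than a number in this assay, so no step among compound 1, compound 2 and compound 3 can be read: the limit of >= 20000 nM in this assay, at which 3 of the 3 values shown sit.

The compounds shown leave open how far each lies beyond that limit, and whether these changes on the phenyl ring alter growth inhibition at all.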